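The source may report more compounds than this note shows. Statements on the series, on what has been measured and on what is new or still open speak of the compounds shown alone.

Compound 1 `COc1cc2c(cc1OC)C(CC(=O)Nc1ccccc1C)CC2` gives 21.9% in a functional assay on the whole organism (strain Wistar) for inhibition, with Rattus norvegicus as the target, read by paw edema, with a stated time of 1 h, at a dose of 100 mg/kg; on this read-out higher numbers stand for more inhibition at the one dose given (going by the name of the read-out) and lower numbers for less inhibition.
Compound 2 `COc1cc2c(cc1OC)C(CC(=O)Nc1ccccn1)CC2` gives 25% in this assay.

Among these two numbers compound 2 stands highest, with compound 1 nearest, but the one measured step, a number 3.1 percentage points higher from compound 1 to compound 2 (within the scatter), lies within the scatter, so the two compounds cannot be separated on this read-out. Compound 3 `COc1cc2c(cc1OC)C(CC(=O)Nc1ccncc1)CC2` has not yet been measured in this assay. It differs from compound 2 in one place: pyridin-4-yl in place of pyridin-2-yl on an amide-type nitrogen. Within the data shown here, no measured step moves the nitrogen within the six-membered aromatic ring on this amide-type nitrogen, so nothing bears directly on the change; the only measured step, a number 3.1 percentage points higher from compound 1 to compound 2 (within the scatter), concerns a different replacement at the same place and stayed within the scatter. On that basis no step beyond the scatter is expected, and the expected step is a number 1 percentage points lower from compound 2 to compound 3 (within the scatter). Compound 3 is therefore estimated to give 24% in this assay, with a range from 10% to 38%.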

Compound 3, a percentage reported as inhibition, in the whole organism at one dose (the size of the read-out at that dose, not a potency): 42.2%
Beside the measured number, compound 3's estimate is 18.2 percentage points below it, and the stated range ends below it.
By their numbers in this assay, from the lowest: compounds 1 and 2 (each within the scatter of the next); then compound 3.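

In this assay this place on the amide-type nitrogen proves sensitive to how the ring is joined, which the earlier pair could not show: with the same atoms, pyridin-4-yl in place of pyridin-2-yl gives a number 17.2 percentage points higher from compound 2 to compound 3 (beyond the scatter). Pyridin-4-yl also separates from 2-methylphenyl, with a number 20.3 percentage points higher from compound 1 to compound 3 (beyond the scatter), so compound 3 alone stands clear of the other two on this read-out, and it stands highest of the three. No evidence is available to explain why the two pyridinyl groups differ.

The compounds shown leave open whether pyridin-3-yl would fall with compound 2 or with compound 3, and whether the ring nitrogen is needed at all, which unsubstituted phenyl or 4-methoxyphenyl on the same amide-type nitrogen could test. They also leave open whether the higher number for compound 3 holds at other doses or times.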